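A methoxy step on compound 2

A few compounds are considered here, and "the series" means these few. Any claim that something is new, unique, unknown or untested is made for them only; others in the source may bear on it.

- compound 1 `Cc1cc(C)nc(NS(=O)(=O)c2ccc(Nc3nncc4ccccc34)cc2)n1`: 0.08 nM
- compound 2 `S=C(NNc1nncc2ccccc12)Nc1ccccc1`: 0.6 nM
- compound 3 `O=S(=O)(Nc1nccs1)c1ccc(Nc2nncc3ccccc23)cc1`: 7.7 nM

In a functional assay on SK-OV-3 cells (Homo sapiens) for antiproliferative activity, read by sulforhodamine B assay, with a stated time of 72 h (a lower number here means a stronger inhibitor, a higher number a weaker inhibitor), compound 2 gives 0.6 nM. This is the middle of the three numbers: compound 1 gives 0.08 nM, a lower number, and compound 3 gives 7.7 nM, a higher one.

The next compound, compound 4 `COc1ccc(NC(=S)NNc2nncc3ccccc23)cc1`, differs from compound 2 by methoxy in place of hydrogen on an aromatic carbon. The change is methoxy in place of hydrogen on an aromatic carbon.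

For the measured compounds named here, only one measured step links two compounds that differ in a single place, a 96-fold higher number from compound 1 to compound 3 (1.98 log units; beyond the scatter). That step is large, but it exchanges 4,6-dimethylpyrimidin-2-yl for 1,3-thiazol-2-yl on a sulfonamide nitrogen, and compound 2 has no such nitrogen. It shows that a single change can move the number a long way in this assay, but it gives neither a size nor a direction for methoxy. Going by the values given here, no measured pair tests methoxy, so the expectation is a small step, leaning only slightly towards a higher number, with wide margins on both sides. The expected change is a 1.7-fold higher number from compound 2 to compound 4 (0.22 log units; within the scatter). For compound 4 the estimated value is 1 nM, with an expected range from 0.15 nM to 7 nM.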

Compound 4, half-maximal inhibitory concentration: 0.8 nM
Compound 4: the middle estimate sits 1.3-fold (0.10 log units) above what was measured; measured number inside the range.
By their numbers in this assay, from the lowest: compound 1; then compounds 2 and 4 (each within the scatter of the next); then compound 3.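

In this assay, the step at this position is a 1.3-fold higher number from compound 2 to compound 4 (0.12 log units; within the scatter), so compound 2 and compound 4 cannot be told apart, and methoxy in place of hydrogen on an aromatic carbon, para to a large group, leaves the activity in the same sub-nanomolar region. For the compounds shown here, the earlier compounds showed only that a single change on a sulfonamide nitrogen can matter a great deal, with a 96-fold higher number from compound 1 to compound 3 (1.98 log units; beyond the scatter), whereas this result shows that a change of a different kind, at a place on the six-membered aromatic ring of carbon only, can add two heavy atoms and one hydrogen-bond acceptor without a step beyond the scatter. No measurement shown here explains why the number holds at this position.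

On these data alone, what remains open is whether this position accepts any group other than methoxy, such as an amine, a carboxylic acid or a longer chain like butoxy, in the same way. As far as these compounds go, it is also open whether methoxy would give so small a step on another carbon of that ring, since a single pair describes one group in one place and supports no wider rule.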